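A few compounds are considered here, and "the series" means these few. Any claim that something is new, unique, unknown or untested is made for them only; others in the source may bear on it.

Measured so far:
compound 1 `CC/N=C(\S)NCCCn1nc(-c2ccccc2)ccc1=O`, a functional assay on the whole organism with Rattus norvegicus as the target (a higher number here means that more compound is needed for the effect, a lower number that less compound is needed), 88.2 mg/kg
compound 2 `CN(C)/C(=N/CCCn1nc(-c2ccccc2)ccc1=O)NC#N`, this assay 93.1 mg/kg

On these numbers compound 2 gives the highest value, but its nearest neighbour is compound 1 with a 1.1-fold higher number from compound 1 to compound 2 (0.02 log units; within the scatter), a step lying within the scatter. Compound 3 `C/N=C(\S)NCCCn1nc(-c2ccccc2)ccc1=O` is not yet measured; it differs from compound 2 by a group of 5 heavy atoms (2 carbon, 2 nitrogen, 1 sulfur; no ring) in place of a group of 8 heavy atoms (4 carbon, 4 nitrogen; no ring), on a saturated chain carbon, three bonds along the chain from an aromatic nitrogen. Going by the values given here, the only step in hand at that position is the one from compound 1 to compound 2, and it stayed within the scatter. A change in this assay beyond the scatter is therefore not expected, and the step from compound 2 to compound 3 is estimated as a 1.0-fold lower number from compound 2 to compound 3 (0.01 log units; within the scatter). Compound 3 is expected to give 90 mg/kg in this assay, within 45 mg/kg to 180 mg/kg.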

Compound 3, dose for half-maximal effect: 58 mg/kg
Estimate against measurement, compound 3: 1.6-fold (0.19 log units) above; the measured number falls inside the stated range.
By their numbers in this assay, from the lowest: compounds 3, 1 and 2 (each within the scatter of the next).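

At the saturated chain carbon, three bonds along the chain from an aromatic nitrogen, the group of 5 heavy atoms in place of the group of 8 heavy atoms gives a 1.6-fold lower number from compound 2 to compound 3 (0.21 log units; within the scatter) in this assay and, like the earlier replacement there, stays within the scatter. Hydrogen in place of methyl on the saturated chain carbon bound to a double-bonded nitrogen gives a 1.5-fold lower number from compound 1 to compound 3 (0.18 log units; within the scatter) and also stays within the scatter, so this smaller change resolves no effect either. Nothing at hand explains these numbers.

Still open, on these data alone, is whether a longer chain on that nitrogen, or an amine or carboxylic acid in place of the whole group, would move this assay beyond the scatter.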